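Chloro in place of fluoro: an expected modest step

The source may report more compounds than this note shows. Statements on the series, on what has been measured and on what is new or still open speak of the compounds shown alone.

In a functional assay on SK-MEL-2 cells (Homo sapiens) for cytotoxicity, read by MTT assay, with a stated time of 72 h (on this read-out lower numbers stand for stronger inhibition and higher numbers for weaker inhibition), compound 1 `O=C1C(Nc2ccc(F)cc2)=CC(=O)c2ncncc21` gives 0.05 ug/mL and holds the highest number of the three measured compounds. Compound 2 `O=C1C(Nc2ccc(I)cc2)=CC(=O)c2ncncc21` at 0.02 ug/mL and compound 3 `O=C1C(Nc2ccc(Br)cc2)=CC(=O)c2ncncc21` at 0.02 ug/mL both sit lower. Compound 4 `O=C1C(Nc2ccc(Cl)cc2)=CC(=O)c2ncncc21` awaits measurement, and chloro in place of fluoro on an aromatic carbon is all that separates it from compound 1. Going by the values given here, two measured steps bear on this change, both modest: a 2.5-fold lower number from compound 1 to compound 2 (0.40 log units; beyond the scatter) for iodo in place of fluoro and a 2.5-fold lower number from compound 1 to compound 3 (0.40 log units; beyond the scatter) for bromo in place of fluoro, while no change at the digits printed from compound 2 to compound 3 (within the scatter) is seen between iodo and bromo. A modest move to lower numbers is therefore expected, with a 2.0-fold lower number from compound 1 to compound 4 (0.30 log units; within the scatter) as the estimated step. For compound 4 the estimated value is 0.025 ug/mL with 0.012 ug/mL to 0.05 ug/mL as its expected range.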

Compound 4, half-maximal inhibitory concentration: 0.01 ug/mL
For compound 4 the middle estimate is 2.5-fold (0.40 log units) above the measured one, outside the stated range (below it).
By their numbers in this assay, from the lowest: compounds 4, 2 and 3 (each within the scatter of the next); then compound 1.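

Chloro in place of fluoro gives a 5.0-fold lower number from compound 1 to compound 4 (0.70 log units; beyond the scatter) and so joins iodo and bromo in parting from fluoro beyond the scatter at this place. The three larger halogens do not separate from one another, with a 2.0-fold lower number from compound 3 to compound 4 (0.30 log units; within the scatter) and a 2.0-fold lower number from compound 2 to compound 4 (0.30 log units; within the scatter) leaving fluoro as the only substituent that stands apart here. Nothing available explains this difference.

From the compounds shown here alone, all four compounds carry a halogen at this place, so it remains open whether an amine, a methoxy group or a carboxylic acid would give similarly low numbers.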